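Ethyl in Place of Ethoxy: An Expected Half-Life Shift

This account rests on a few compounds, and the source may have more. Where it says the series, first, only, none or still open, it means among the compounds named here.

Compound 1 `CCOc1nc(-c2ccc(Cl)cc2Cl)c(CC)nc1NC(CC)CC` is one of two measured compounds. For the measured compounds named here, in an in vitro ADME assay on microsomes (Rattus norvegicus) for metabolic stability (a higher number here means that the compound lasts longer, a lower number that the compound disappears faster), compound 1 gives 1.23 h, the only numerical value among the two. Compound 2 `CCc1nc(-c2cnc(OC)nc2OC)c(CC)nc1NC(CC)CC` is the other. In this assay compound 2 reaches only a limit of the assay, < 0.0167 h, and (the limit of < 0.0167 h in this assay, at which 1 of the 2 values shown sits). Compound 3 `CCc1nc(-c2ccc(Cl)cc2Cl)c(CC)nc1NC(CC)CC` is not yet measured; it differs from compound 1 by ethyl in place of ethoxy on an aromatic carbon. Going by the values given here, no single-place step between measured compounds exists. Compound 3 is expected to give 0.5 h, between 0.12 h and 2 h. The step of a 2.5-fold lower number from compound 1 to compound 3 (0.39 log units; beyond the scatter) is expected to run downward, somewhat beyond the usual scatter.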

Compound 3, half-life: 0.07 h
Estimate against measurement, compound 3: 7.1-fold (0.85 log units) above; the measured number lies below the stated range.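

In this assay, for the compounds shown here, the first single-place step gives an 18-fold lower number from compound 1 to compound 3 (1.24 log units; beyond the scatter), for ethyl in place of ethoxy on the aromatic carbon next to the ring nitrogen. With the 2,4-dichlorophenyl and (pentan-3-yl)amino groups unchanged, this position is clearly not indifferent, and of this pair the ethoxy compound lasts longer. On these data alone, whether a methoxy group, a propoxy chain or an amine on this carbon would last as long as ethoxy remains open. Nothing shown bears on the cause of this step.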